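The compounds below may be only part of what the source reports. "The series", "measured", "known", "first", "only" and "open" are said of these compounds alone.

Measured so far in an ADME assay on NIH3T3 cells (Mus musculus) for cytotoxicity, read by MTT assay, with a stated time of 24 h; on this read-out lower numbers stand for stronger inhibition and higher numbers for weaker inhibition:

compound 1 `Cc1ccc(-c2cs/c(=N/NC(=O)CSc3nnnn3-c3ccccc3)n2-c2ccccc2)cc1` gives > 500 ug/mL, a limit of the assay.
compound 2 `Cn1nnnc1SCC(=O)N/N=c1/scc(-c2ccccc2)n1-c1ccccc1` gives 173 ug/mL.
compound 3 `Cc1nnc(SCC(=O)N/N=c2/scc(-c3ccc(C#N)cc3)n2-c2ccccc2)s1` gives < 3.9 ug/mL, again a limit of the assay.

Compound 3 stands at the limit of < 3.9 ug/mL in this assay, at which 1 of the 3 values shown sits, so the read-out gives no number for it, only the boundary. For the measured compounds named here, compound 1 sits at the other boundary, (the limit of > 500 ug/mL in this assay, at which 1 of the 3 values shown sits), while compound 2 is the one compound of the three with a proper number in this assay. Going by the values given here, no pair among the three differs in a single place, so no measured step can be drawn.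

Compound 4 `Cn1cnnc1SCC(=O)N/N=c1/scc(-c2ccc(C#N)cc2)n1-c1ccccc1` is not yet measured. It is derived from compound 3 by the change 4-methyl-4H-1,2,4-triazol-3-yl in place of 5-methyl-1,3,4-thiadiazol-2-yl on a sulfur

Both azoles carry a methyl; the two ring systems are the same size, and only the ring atoms change. Among the compounds with values here, compound 2, which also carries a methylated nitrogen-rich five-membered azole on the sulfur, is far from the lower boundary, but its aryl group on the core is not the one compound 3 carries, so it does not give a clean comparison.

The expectation is a step in this assay from compound 3 to compound 4 toward weaker inhibition, an at least 7.6-fold higher number from compound 3 to compound 4 (0.88 log units; beyond the scatter), beyond the scatter but uncertain in size. Compound 4 is estimated at 30 ug/mL, with a range from 5 ug/mL to 200 ug/mL.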

Compound 4, half-maximal inhibitory concentration: 153 ug/mL
For compound 4 the middle estimate is 5.1-fold (0.71 log units) below the measured one; low and high end bracket the measured number.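

In this assay, for the compounds shown here, the exchange of 5-methyl-1,3,4-thiadiazol-2-yl for 4-methyl-4H-1,2,4-triazol-3-yl on a sulfur gives an at least 39-fold higher number from compound 3 to compound 4 (1.59 log units; beyond the scatter) and is the first single-place comparison. It shows that the group on this sulfur can by itself shift the read-out well beyond the scatter, with the rest of the molecule held the same and the heavy-atom count of the group unchanged, a separation that compounds 1 and 2 could not provide. Going by these compounds, the true size of the step remains unknown because compound 3 has a limit and not a number: the limit of < 3.9 ug/mL in this assay, at which 1 of the 4 values shown sits.

The compounds shown leave open whether this exchange gives a step of similar size with a different aryl group on the shared core, and whether the ring atoms or the place of the methyl accounts for it. Also open, on these data alone, is where an aminoethyl chain or a carboxymethyl group on the same sulfur would fall in this assay relative to these two azoles.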